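Swapping the Benzyl Group on a Sulfonamide Chain

The compounds below may be only part of what the source reports. "The series", "measured", "known", "first", "only" and "open" are said of these compounds alone.

Compound 2 `O=S(=O)(NCCCNCc1ccccc1Cl)c1cc(C(F)(F)F)cc(C(F)(F)F)c1` and compound 1 `O=S(=O)(NCCNCc1cccc2ccccc12)c1cc(C(F)(F)F)cc(C(F)(F)F)c1` are built on a shared core and differ in their amine-bearing tail. In a functional assay on MCF7 cells (Homo sapiens) for inhibition, read by MTT assay, with a stated time of 72 h (on this read-out lower numbers stand for stronger inhibition of growth and higher numbers for weaker inhibition of growth), compound 2 gives 8800 nM, and compound 1 gives 18000 nM; of these two numbers compound 2 has the lower one, and its gap to compound 1 lies beyond the usual scatter of this assay.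

Compound 3 `CC(C)(C)c1ccc(CNCCCNS(=O)(=O)c2cc(C(F)(F)F)cc(C(F)(F)F)c2)cc1` has not yet been measured. It differs from compound 2 in one place: 4-(tert-butyl)phenyl in place of 2-chlorophenyl on a saturated chain carbon bound to an amine nitrogen. Among the compounds with values here, no measured pair shows this exchange, so there is no step to lean on, and the two measured compounds give no guidance on it. The expected step in this assay is a 1.1-fold lower number from compound 2 to compound 3 (0.04 log units; within the scatter), which stays within the scatter and carries no clear direction. Compound 3 is therefore estimated to give about 8000 nM, expected to fall between 3000 nM and 25000 nM.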

Compound 3, concentration for 50% growth inhibition: 2100 nM
Estimate against measurement, compound 3: 3.8-fold (0.58 log units) above; the whole stated range lies above it.
By their numbers in this assay, from the lowest: compound 3; then compound 2; then compound 1.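

Within the data shown here, this is the first exchange here confined to one place, since compound 1 and compound 2 differ in more than the benzyl group. It shows that the group on this saturated chain carbon matters: in this assay, replacing 2-chlorobenzyl with 4-(tert-butyl)benzyl gives a 4.2-fold lower number from compound 2 to compound 3 (0.62 log units; beyond the scatter), a change that lies beyond the usual scatter, and the position accepts the exchange with a gain in growth inhibition. Nothing available explains why this exchange lowers the number.

Among these compounds, the single exchange removes the chlorine and adds the tert-butyl group together, so it remains open which of the two changes accounts for the step. As far as these compounds go, a plain benzyl group on the same chain would help separate them, and it remains unknown whether 4-(tert-butyl)benzyl would have the same effect on a shorter or longer chain.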